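One Carbonyl Substituent Exchanged on Compound 3

The source may report more compounds than this note shows. Statements on the series, on what has been measured and on what is new or still open speak of the compounds shown alone.

In an ADME assay on HEK293 cells (Homo sapiens) for cytotoxicity, read by resazurin assay, with a stated time of 48 h (a higher number here means that more compound is tolerated, a lower number that less compound is tolerated), compound 1 `COc1ccc(S(=O)(=O)Nc2ccc(-c3nc4cc(NS(=O)(=O)c5ccc(OC)cc5)ccc4o3)cc2)cc1` gives 48000 nM and compound 2 `O=S(=O)(Nc1ccc(-c2nc3cc(NS(=O)(=O)c4cccc(C(F)(F)F)c4)ccc3o2)cc1)c1cccc(C(F)(F)F)c1` gives 23000 nM. Compound 3 `COc1ccc(S(=O)(=O)Nc2ccc3oc(-c4ccc(NC(=O)c5cccc(C)c5[N+](=O)[O-])cc4)nc3c2)cc1` gives 12000 nM, which is within the usual scatter of compound 2 and clearly lower than compound 1. Compound 4 `COc1ccc(S(=O)(=O)Nc2ccc3oc(-c4ccc(NC(=O)c5ccc(Cl)s5)cc4)nc3c2)cc1` carries 5-chlorothiophen-2-yl in place of 3-methyl-2-nitrophenyl on a carbonyl carbon. Among the measured compounds shown here, the one measured step bearing on this is a 4.0-fold lower number from compound 1 to compound 3 (0.60 log units; beyond the scatter), a modest change that put a carbonyl group where a sulfonyl group stood. For the measured compounds named here, in compound 4 the carbonyl stays, and no measured step shows what this exchange does. The expected change is small, a 1.3-fold higher number from compound 3 to compound 4 (0.10 log units; within the scatter), with no shift beyond the scatter in this assay. For compound 4 the estimate is 15000 nM, with an expected range from 6000 nM to 40000 nM.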

Compound 4, half-maximal cytotoxic concentration: 15000 nM
Estimate against measurement, compound 4: no gap at the digits printed; measured number inside the range.
By their numbers in this assay, from the lowest: compounds 3, 4 and 2 (each within the scatter of the next); then compound 1.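

In this assay the exchange on the carbonyl carbon gives a 1.3-fold higher number from compound 3 to compound 4 (0.10 log units; within the scatter), so 5-chlorothiophen-2-yl and 3-methyl-2-nitrophenyl are not told apart at this place, even though they differ in ring and in size. The other new step, a 3.2-fold lower number from compound 1 to compound 4 (0.51 log units; beyond the scatter), lies beyond the scatter, as the step to compound 3 did, so a second carbonyl compound also stands apart from compound 1. Nothing measured here explains these numbers. The compounds shown carry only aromatic rings on this carbonyl carbon, so what a longer chain or an amine would do there stays open.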